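The source may hold more compounds than are shown below. What is called first, only, known or untested is meant among the compounds shown, and "the series" means these compounds.

Three compounds of a shared core, `O=C(/C=C\Nc1ccc(F)cc1)c1nc(-c2ccc(F)cc2)n2ccccc12` for compound 1, `O=C(/C=C\Nc1ccc2cc[nH]c2c1)c1nc(-c2ccc(C(F)(F)F)cc2)n2ccccc12` for compound 2 and `O=C(/C=C\Nc1ccc2[nH]ccc2c1)c1nc(-c2ccc(C(F)(F)F)cc2)n2ccccc12` for compound 3, have been tested in a functional assay on A549 cells (Homo sapiens) for cytotoxicity, read by MTT assay, with a stated time of 48 h; on this read-out lower numbers stand for stronger inhibition and higher numbers for weaker inhibition. In this assay compound 1 gives 13200 nM and compound 3 gives 5190 nM. Compound 2 reaches only a limit of the assay, > 30000 nM, at which one of the three values sits, as the limit of > 30000 nM in this assay, at which 1 of the 3 values shown sits, records. Among the two full numbers compound 1 stands highest, with compound 3 the nearest and lower by a gap that lies beyond the usual scatter. Within the data shown here, the one single-point step measured so far, an at least 5.7-fold lower number from compound 2 to compound 3 (0.76 log units; beyond the scatter), moves the indole attachment on the amine nitrogen and is the only guide to how this series responds to changes at that position.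

Compound 4, `O=C(/C=C\Nc1ccc(Cl)cc1)c1nc(-c2ccc(F)cc2)n2ccccc12`, differs from compound 1 by chloro in place of fluoro on an aromatic carbon. Among the measured compounds shown here, no measured step touches this part of the molecule, so the expectation rests only on the spread of the three values and on the fact that the aryl ring attached to the amine nitrogen is kept. Compound 4 is therefore expected to land near compound 1, with an estimated step of a 1.3-fold lower number from compound 1 to compound 4 (0.12 log units; within the scatter) that stays within the scatter. For compound 4 the estimate in this assay is 10000 nM, in a range from 4000 nM to 25000 nM.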

Compound 4, half-maximal inhibitory concentration: 5090 nM
Compound 4: the middle estimate sits 2.0-fold (0.29 log units) above what was measured, and the stated range covers the measured number.
By their numbers in this assay, from the lowest: compounds 4 and 3 (each within the scatter of the next); then compound 1. At a limit, above all of these: compound 2.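

Among these compounds, until now, the only measured change on the amine side of this series was the shift of the indole attachment, which left open whether a smaller edit to the aryl ring on the amine nitrogen would register at all. The exchange of (4-fluorophenyl)amino for (4-chlorophenyl)amino shows that it does: with the rest of the molecule kept, this assay records a 2.6-fold lower number from compound 1 to compound 4 (0.41 log units; beyond the scatter). A swap of one halogen for another on an aromatic carbon, para to a large group, is therefore enough to shift the read-out modestly, though nothing given here accounts for why this step occurs.

Going by these compounds, whether a bromo, methyl or methoxy group in the same place would continue this shift, or reverse it, remains open, as does how a plain phenyl ring with hydrogen there would compare. On these data alone, it is also open whether the same exchange of fluoro for chloro would give a similar step on a compound carrying the 4-(trifluoromethyl)phenyl group of compound 3, or whether the step belongs only to the setting of compound 1.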